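Adding a third methoxy group to a chalcone-type series

The source may hold more compounds than are shown below. What is called first, only, known or untested is meant among the compounds shown, and "the series" means these compounds.

Compound 1 `C=C(Br)C(=O)Nc1ccc(C(=O)/C=C/c2ccccc2)cc1` is the parent of this small set. In a functional assay on HeLa cells (Homo sapiens) for antiproliferative activity, with a stated time of 48 h (on this read-out higher numbers stand for weaker inhibition and lower numbers for stronger inhibition), compound 1 gives 960 nM. Compound 2 `C=C(Br)C(=O)Nc1ccc(C(=O)/C=C/c2cccc(OC)c2)cc1` carries methoxy in place of hydrogen on an aromatic carbon, and in this assay compound 2 gives 500 nM; the step of a 1.9-fold lower number from compound 1 to compound 2 (0.28 log units; within the scatter) is small. Compound 3 `C=C(Br)C(=O)Nc1ccc(C(=O)/C=C/c2ccc(OC)cc2OC)cc1` has a different core, and the difference between the core of compound 1 and the core of compound 3 is not broken down here. In this assay compound 3 gives 1100 nM, which sits close to the number for compound 1 and beyond the scatter from the number for compound 2.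

Compound 4 `C=C(Br)C(=O)Nc1ccc(C(=O)/C=C/c2ccc(OC)c(OC)c2OC)cc1` is not yet measured. It differs from compound 3 by methoxy in place of hydrogen on an aromatic carbon. Going by the values given here, this is the same kind of change as the one from compound 1 to compound 2, but the place differs: in compound 4 the new methoxy sits ortho to two methoxy groups, whereas in compound 2 it sits only meta to a large group. Because the earlier step of a 1.9-fold lower number from compound 1 to compound 2 (0.28 log units; within the scatter) stayed within the scatter, a step of similar size is expected for compound 4 in this assay, a 1.2-fold lower number from compound 3 to compound 4 (0.09 log units; within the scatter). The estimated result for compound 4 is 900 nM, with a range from 400 nM to 2200 nM.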

Compound 4, half-maximal inhibitory concentration: 510 nM
Estimate against measurement, compound 4: 1.8-fold (0.25 log units) above; the measured number falls inside the stated range.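

In this assay, placing methoxy in place of hydrogen on an aromatic carbon gives a 2.2-fold lower number from compound 3 to compound 4 (0.33 log units; beyond the scatter), a modest step. Set beside the earlier case, the change gives steps of similar size on the two cores: the same change on two cores in this assay, a 1.9-fold lower number (0.28 log units; within the scatter) from compound 1 to compound 2 and a 2.2-fold lower number (0.33 log units; beyond the scatter) from compound 3 to compound 4, 1.1-fold (0.05 log units) apart, within the scatter of two such steps. Going by these compounds alone, this suggests that the effect of the change carries over between these two cores, but the case rests on only two pairs, one of which stays within the scatter on its own, and it shows nothing about other cores or about methoxy on other aromatic carbons.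

Every group added to the aromatic ring in the compounds shown is a methoxy group, and how an amine or a carboxylic acid in its place would read in this assay stays open. Also open, from the compounds shown here alone, is what would happen if the bromine shared by all four compounds were replaced with chlorine.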